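Compound 3 to compound 4: swapping one group for 2H-tetrazol-5-yl

The source may hold more compounds than are shown below. What is called first, only, known or untested is meant among the compounds shown, and "the series" means these compounds.

Going by the values given here, in an ADME assay on microsomes from liver (Rattus norvegicus) for metabolic stability, with a stated time of 10 min, tested at 0.5 uM (a lower number here means that less of the compound is left, a higher number that more of the compound is left), compound 3 (`C[C@@H](OC(=O)c1cc(Cl)cc2cc(CNC(=O)c3cnn4cccnc34)oc12)C(F)(F)F`) gives 0% and holds the lowest of the three numbers so far, beyond the scatter from both others. Compound 1 (`O=C(NCc1cc2cc(Cl)cc(C(=O)O)c2o1)c1cncc2cccnc12`) reads 64% in the same measurement and compound 2 (`O=C(O)c1cc(Cl)cc2cc(CNC(=O)c3cnn4cccnc34)oc12`) reads 100% there.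

Compound 4 (`O=C(NCc1cc2cc(Cl)cc(-c3nn[nH]n3)c2o1)c1cnn2cccnc12`) has not yet been measured. It differs from compound 3 at one place, with 2H-tetrazol-5-yl in place of (1-(trifluoromethyl)ethoxy)carbonyl on an aromatic carbon.

Among the compounds with values here, the one measured step at this place is a number 100 percentage points lower from compound 2 to compound 3 (beyond the scatter) and it comes with 1-(trifluoromethyl)ethyl in place of hydrogen on an oxygen next to a carbonyl group. Compound 4 no longer carries that 1-(trifluoromethyl)ethyl, which points to a large move upward. Within the data shown here, no measured step brings in 2H-tetrazol-5-yl, however, so the size stays uncertain. On these data alone, compound 1 also lacks the 1-(trifluoromethyl)ethyl and reads 64% so a number short of that of compound 2 remains open.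

The expected change is large and upward, estimated as a number 80 percentage points higher from compound 3 to compound 4 (beyond the scatter) in this assay overall. The estimate for compound 4 is 80% (expected range 50% to 100%).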

Compound 4, percent of the compound remaining: 89%
Compound 4: middle estimate off by 9 percentage points, on the low side; the range from low to high includes it.
By their numbers in this assay, from the lowest: compound 3; then compound 1; then compound 4; then compound 2.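

In this assay, putting 2H-tetrazol-5-yl in place of (1-(trifluoromethyl)ethoxy)carbonyl on this aromatic carbon gives a number 89 percentage points higher from compound 3 to compound 4 (beyond the scatter), so the loss seen with that group is not shared by every replacement at this position. The earlier compounds shown here offered no alternative to the carboxy group here, and 2H-tetrazol-5-yl in its place gives a number 11 percentage points lower from compound 2 to compound 4 (beyond the scatter), a modest cost set against a number 100 percentage points lower from compound 2 to compound 3 (beyond the scatter) for the change to the (1-(trifluoromethyl)ethoxy)carbonyl group. Nothing among the available data accounts for the difference between these groups.

The compounds shown leave open how other groups on this aromatic carbon would read, such as a primary amide or a plain methyl ester, and the latter would help separate the part played by the trifluoromethyl from that of the ester itself. They also leave open whether 2H-tetrazol-5-yl would read the same way when carried with the other amide part found in compound 1.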